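The source may hold more compounds than are shown below. What is called first, only, known or untested is meant among the compounds shown, and "the series" means these compounds.

Notes on the series. Compound 2 `CC#CCn1c(N2CCC[C@@H](N)C2)nc2c1c(=O)n(Cc1cc(C#N)ccc1C(=O)O)c(=O)n2C` stands only as a limit in an ADME assay on isolated protein for inhibition of Dipeptidyl peptidase 9 (Homo sapiens), with stated times of 15 min, 60 s and 20 min; on this read-out lower numbers stand for stronger inhibition and higher numbers for weaker inhibition; in this assay compound 2 gives > 100000 nM. Compound 1 `CC#CCn1c(N2CCC[C@@H](N)C2)nc2c1c(=O)n(Cc1c(Cl)cccc1C(=O)OC)c(=O)n2C` also gives only a limit in this assay, > 100000 nM. Compound 3 `CC#CCn1c(N2CCC[C@@H](N)C2)nc2c1c(=O)n(Cc1c(Cl)cccc1C(=O)O)c(=O)n2C` likewise gives only a limit in this assay, > 100000 nM. Every measured value therefore sits at the limit of > 100000 nM in this assay, at which 3 of the 3 values shown sit, and none of the steps among the three can be read: a step that the two limits leave unreadable from compound 1 to compound 2, a step that the two limits leave unreadable from compound 1 to compound 3, a step that the two limits leave unreadable from compound 2 to compound 3.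

Compound 4 `CC#CCn1c(N2CCC[C@@H](N)C2)nc2c1c(=O)n(Cc1ccc(Cl)cc1C(=O)OCC)c(=O)n2C` is not yet measured. Its difference from compound 2 is 4-chloro-2-(ethoxycarbonyl)phenyl in place of 2-carboxy-5-cyanophenyl on a saturated chain carbon bound to an aromatic nitrogen. Going by the values given here, the steps that bear on this change are the two that lead into or out of compound 2, and both are unreadable because each end sits at the limit of > 100000 nM in this assay, at which 3 of the 3 values shown sit. With every value a limit, no direction or size of step beyond the scatter can be read from the series, and the expectation rests on the limits alone. Compound 4 is expected to give 100000 nM in this assay, with an estimated range from 30000 nM to 300000 nM. The expected step is a number no higher from compound 2 to compound 4 (the limit leaves the size open).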

Compound 4, half-maximal inhibitory concentration: > 100000 nM
Compound 4: only a limit was reported; the forecaster's own chance of this, stated with the estimate: 85%; the middle value sits exactly at the limit.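

In this assay compound 4 gives > 100000 nM as a limit. No new step can be read between compound 4 and compound 1, compound 2 or compound 3: the limit of > 100000 nM in this assay, at which 4 of the 4 values shown sit. The compounds shown leave open whether any group on the saturated chain carbon changes the read-out, and by how much.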